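Amide to amino ester swap on the shared core

A few compounds are considered here, and "the series" means these few. Any claim that something is new, unique, unknown or untested is made for them only; others in the source may bear on it.

Compound 1 `Cc1noc(NS(=O)(=O)c2cccc3c(NC(=O)C(C)C)cccc23)c1C` is measured in an assay on VSM-A10 cells for antagonist activity at Endothelin-1 receptor (Rattus norvegicus) (a higher number here means a weaker inhibitor, a lower number a stronger inhibitor), at 880 nM, the lowest of the two numbers recorded so far. Among the measured compounds shown here, compound 2 `Cc1noc(NS(=O)(=O)c2cccc3c(N(C)C)cccc23)c1[N+](=O)[O-]` gives 17300 nM in this assay, a gap well beyond the usual scatter, and no single-change step links these two compounds. Compound 3 `CCOC(=O)C(C)Nc1cccc2c(S(=O)(=O)Nc3onc(C)c3C)cccc12` has not been measured; it differs from compound 1 by 1-(ethoxycarbonyl)ethyl in place of isopropylcarbonyl on a nitrogen on an aromatic ring. For the measured compounds named here, no measured step covers a change of this kind, so the step is expected to be modest and toward a higher number, a 1.7-fold higher number from compound 1 to compound 3 (0.23 log units; within the scatter). Compound 3 is therefore estimated at 1500 nM, with a range of 400 nM to 6000 nM.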

Compound 3, half-maximal inhibitory concentration: 400 nM
Compound 3: the middle estimate sits 3.8-fold (0.57 log units) above what was measured; the measured number falls inside the stated range.
By their numbers in this assay, from the lowest: compound 3; then compound 1; then compound 2.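

In this assay the nitrogen on an aromatic ring takes 1-(ethoxycarbonyl)ethyl in place of isopropylcarbonyl with a 2.2-fold lower number from compound 1 to compound 3 (0.34 log units; beyond the scatter) as the first step measured at this position. In this pair, the amide carbonyl directly on that nitrogen is therefore not needed to keep inhibition, and the larger ester-bearing group is accepted there.

From the compounds shown here alone, whether the ethyl ester contributes remains open; the matching carboxylic acid or a simple isopropyl group on the same nitrogen would separate the ester from the chain. What lies behind the step has no measurement to support an explanation.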